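Chloro in place of fluoro: from compound 2 to compound 3

The compounds below may be only part of what the source reports. "The series", "measured", "known", "first", "only" and "open" are said of these compounds alone.

In a functional assay on HL-60 cells (Homo sapiens) for antiproliferative activity, read by MTT assay, with a stated time of 48 h (a higher number here means a weaker inhibitor, a lower number a stronger inhibitor), compound 1 `O=C(CCCCCC(=O)Nc1ccc(O)c(C(=O)Nc2ccccc2)c1)NO` gives 20300 nM. Compound 2 `O=C(CCCCCC(=O)Nc1ccc(O)c(C(=O)Nc2ccc(F)c(F)c2)c1)NO` reads > 100000 nM, which is a limit of the assay and not a number. Its standing is thus (the limit of > 100000 nM in this assay, at which 1 of the 2 values shown sits).

Compound 3 `O=C(CCCCCC(=O)Nc1ccc(O)c(C(=O)Nc2ccc(F)c(Cl)c2)c1)NO` differs from compound 2 in one place: chloro in place of fluoro on an aromatic carbon. This is chloro in place of fluoro on an aromatic carbon, ortho to a fluoro group. Within the data shown here, the one measured step that bears on it is an at least 4.9-fold higher number from compound 1 to compound 2 (0.69 log units; beyond the scatter), where 3,4-difluorophenyl replaces phenyl. Among the measured compounds shown here, no measured step involves chloro, so that step gives only a loose guide. In this assay the expected at least 1.2-fold lower number from compound 2 to compound 3 (0.09 log units; that floor lies within the scatter) is small, towards a lower number if it can be resolved at all, and compound 3 may also end at the limit. For compound 3 the estimate is 80000 nM, with an expected range of 25000 nM to 200000 nM.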

Compound 3, half-maximal inhibitory concentration: > 100000 nM
Compound 3 was reported as a limit; the forecaster's own chance of this, stated with the estimate: 50%; middle value at least 1.2-fold (0.09 log units) away from the limit.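

In this assay compound 3 reads > 100000 nM, which is a limit of the assay and not a number. Set against the plain phenyl, the change gives an at least 4.9-fold higher number from compound 1 to compound 3 (0.69 log units; beyond the scatter), so the loss seen with 3,4-difluorophenyl also holds for 3-chloro-4-fluorophenyl and is not confined to the difluoro pattern. The step between compound 2 and compound 3 cannot be read, as both are limits, and the series now gathers at the top of the measurable range: the limit of > 100000 nM in this assay, at which 2 of the 3 values shown sit.

As far as these compounds go, whether chloro and fluoro differ at all at this position remains open, as does which of the two halogens in 3-chloro-4-fluorophenyl carries the loss. Also open, from the compounds shown here alone, is how a phenyl bearing a methoxy or an amino group would compare with compound 1 at 20300 nM.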